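The compounds below may be only part of what the source reports. "The series", "measured", "known", "first", "only" and "open" are said of these compounds alone.

Measured so far:
- Compound 1, `NS(=O)(=O)c1ccc(Nc2nc(N/N=C/c3ccc(C(F)(F)F)cc3)nc(Nc3ccccc3)n2)cc1`: in a functional assay on MDA-MB-468 cells (Homo sapiens) for inhibition, read by sulforhodamine B assay, with a stated time of 48 h (a lower number here means that less compound is tolerated, a higher number that more compound is tolerated), compound 1 gives 8630 nM.
- Compound 2, `Cc1nn(-c2ccccc2)cc1/C=N/Nc1nc(Nc2ccccc2)nc(Nc2ccc(S(N)(=O)=O)cc2)n1`: in this assay compound 2 gives 7030 nM.

Compound 2 gives the lower of the two numbers, but its nearest neighbour, compound 1, sits only a small distance away, and that gap is within the scatter, so the two compounds cannot be told apart on these data.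

Compound 3, `NS(=O)(=O)c1ccc(Nc2nc(N/N=C/c3ccccn3)nc(Nc3ccccc3)n2)cc1`, differs from compound 2 in one place: pyridin-2-yl in place of 3-methyl-1-phenyl-1H-pyrazol-4-yl on a carbon with a double bond to nitrogen. Within the data shown here, the only measured step that bears on this position is the one from compound 1 to compound 2, which swapped one ring group for another at the same carbon and gave a 1.2-fold lower number from compound 1 to compound 2 (0.09 log units; within the scatter). That single step suggests the group on this carbon has little effect on the read-out. The expected change in this assay for compound 3 is therefore a 1.1-fold higher number from compound 2 to compound 3 (0.06 log units; within the scatter), no more than the scatter, in no firm direction. For compound 3 the estimate in this assay is 8000 nM, within 3500 nM to 18000 nM.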

Compound 3, concentration lethal to 50% of the cells: > 100000 nM
Compound 3: no number, only a limit; the forecaster's own chance of this, stated with the estimate: 10%; at least 12-fold (1.09 log units) between middle value and limit.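

The group on this carbon is not a silent one after all: in this assay, pyridin-2-yl in place of 3-methyl-1-phenyl-1H-pyrazol-4-yl gives an at least 14-fold higher number from compound 2 to compound 3 (1.15 log units; beyond the scatter). Pyridin-2-yl in place of 4-(trifluoromethyl)phenyl gives a step of the same kind, an at least 11-fold higher number from compound 1 to compound 3 (1.06 log units; beyond the scatter), so the two earlier groups, which could not be told apart, both part clearly from pyridin-2-yl. On these data alone, compound 3 has only a limit of the assay and not a number, so the full size of both steps stays unknown: the limit of > 100000 nM in this assay, at which 1 of the 3 values shown sits.

Still open, as far as these compounds go, is whether the ring nitrogen of pyridin-2-yl drives this step or the change to a single ring does; an unsubstituted phenyl or a pyridin-3-yl on this carbon would separate the two. Also open, from the compounds shown here alone, is how a ring carrying an amine or a carboxylic acid would read here.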